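Dihydroxyphenyl for dimethoxyphenyl on two sulfonamide scaffolds

The source may report more compounds than this note shows. Statements on the series, on what has been measured and on what is new or still open speak of the compounds shown alone.

Compound 1 `COc1ccc(Oc2ccc(C(C)C)cc2-c2ccsc2S(=O)(=O)NCCNC(=O)Nc2cc(Cl)cc(Cl)c2)cc1OC` and compound 2 `CC(C)c1ccc(Oc2ccc(O)c(O)c2)c(-c2ccsc2S(=O)(=O)NCCNC(=O)Nc2cc(Cl)cc(Cl)c2)c1` differ in one place, (3,4-dihydroxyphenyl in place of 3,4-dimethoxyphenyl on an oxygen on an aromatic ring). In a functional assay on HeLa cells (Homo sapiens) for inhibition, read by CCK-8 assay, with a stated time of 48 h (a higher number here means a weaker inhibitor, a lower number a stronger inhibitor), compound 1 gives 11600 nM. Compound 2 reaches only the limit of this assay, > 50000 nM. That change therefore brought an at least 4.3-fold higher number from compound 1 to compound 2 (0.63 log units; beyond the scatter). Compound 3 `COc1ccc(Oc2ccccc2-c2ccsc2S(=O)(=O)N2CCN(C(=S)Nc3ccc(Cl)cc3)CC2)cc1OC` carries a core whose difference from compound 1 is not broken down here. In this assay compound 3 likewise stands at the assay limit, > 50000 nM. Compound 4 `O=S(=O)(c1sccc1-c1ccccc1Oc1ccc(O)c(O)c1)N1CCN(C(=S)Nc2ccc(Cl)cc2)CC1` differs from compound 3 by the same change, (3,4-dihydroxyphenyl in place of 3,4-dimethoxyphenyl on an oxygen on an aromatic ring), at the same kind of place. The expectation rests on the step from compound 1 to compound 2 and on compound 3 already sitting at the limit of > 50000 nM in this assay, at which 2 of the 3 values shown sit. Compound 4 is thus expected to give about 60000 nM, most likely between 30000 nM and 150000 nM, an expected step that the limit leaves unreadable from compound 3 to compound 4, probably reported again as a limit.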

Compound 4, half-maximal inhibitory concentration: > 50000 nM
Compound 4: no number, only a limit (the forecaster's own chance of this, stated with the estimate: 85%); the middle value is on the limit's open side.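

In this assay, among these compounds, compound 4 gives > 50000 nM, which is a limit, as is the value of compound 3, so no step between compound 3 and compound 4 can be read. The compounds shown leave open whether 3,4-dihydroxyphenyl in place of 3,4-dimethoxyphenyl changes anything on the core of compound 3.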